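The compounds below may be only part of what the source reports. "The series", "measured", "known", "first", "only" and "open" are said of these compounds alone.

Measured so far:
compound 1 `Cc1ccc(Nc2nc(-n3ccnc3C)cs2)cc1` — 530 nM
compound 2 `COc1cccc(C(=O)c2sc(Nc3ccccc3)nc2N)c1` — 1700 nM
compound 3 `COc1cc(C(=O)c2sc(Nc3ccc(C)cc3)nc2N)cc(OC)c1OC` — 86 nM

All three numbers come from a functional assay on HeLa cells (Homo sapiens) for antiproliferative activity, read by cell counting, with a stated time of 2 days; a lower number here means a stronger inhibitor, a higher number a weaker inhibitor. Compound 3 holds the lowest of the three; the nearest is compound 1, a gap beyond the scatter, and compound 2 lies further off, also beyond the scatter. No two of these compounds differ in a single place, so no single step has been measured and the series gives no direct reading of the change at hand. Compound 4 `COc1cc(C(=O)c2sc(Nc3ccc(F)cc3)nc2N)cc(OC)c1OC` is compound 3 with fluoro in place of methyl on an aromatic carbon. Nothing measured here isolates this change, so the expected step in this assay is none beyond the scatter, with perhaps a slightly higher number. The estimated step from compound 3 to compound 4 is a 1.4-fold higher number from compound 3 to compound 4 (0.14 log units; within the scatter). Compound 4 is expected to give 120 nM, in the range 40 nM to 400 nM.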

Compound 4, half-maximal inhibitory concentration: 440 nM
The estimate for compound 4 lay 3.7-fold (0.56 log units) below the measured number, outside the stated range (above it).
By their numbers in this assay, from the lowest: compound 3; then compounds 4 and 1 (each within the scatter of the next); then compound 2.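

Among the compounds shown here, this is the first single-place step. In this assay, going from 4-methylphenyl to 4-fluorophenyl on the amino group gives a 5.1-fold higher number from compound 3 to compound 4 (0.71 log units; beyond the scatter), so this position does not tolerate the change freely, and here methyl gives the lower number of the two groups. No available evidence bears on the reason for this step.

Still open, going by these compounds, is whether chloro, methoxy, ethyl or an amine at this position would match methyl or improve on it. Also open, on these data alone, is whether the same change behaves alike with other groups on the carbonyl.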